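Acetyl for Ethyl on the Hydroxylated Analogue

This account rests on a few compounds, and the source may have more. Where it says the series, first, only, none or still open, it means among the compounds named here.

Compound 1, `CCN1CCN(C(=S)SCC(=O)N(Cc2ccc(OC)cc2)c2cc(OC)c(OC)c(OC)c2)CC1`: in a functional assay on HCT-116 cells (Homo sapiens) for inhibition, read by CCK-8 assay, with a stated time of 48 h (a lower number here means a stronger inhibitor, a higher number a weaker inhibitor), compound 1 gives 7700 nM.
Compound 2, `COc1ccc(CN(C(=O)CSC(=S)N2CCN(C(C)=O)CC2)c2cc(OC)c(OC)c(OC)c2)cc1`: compound 2 gives 1370 nM.
Compound 3, `CCN1CCN(C(=S)SCC(=O)N(Cc2ccc(OC)c(O)c2)c2cc(OC)c(OC)c(OC)c2)CC1`: compound 3 gives 530 nM.

Two changes branch out from compound 1. The first, (acetyl in place of ethyl on an amine nitrogen in a ring), produced a 5.6-fold lower number from compound 1 to compound 2 (0.75 log units; beyond the scatter). The second, (hydroxy in place of hydrogen on an aromatic carbon), produced a 15-fold lower number from compound 1 to compound 3 (1.16 log units; beyond the scatter), and it is this change that separates the core of compound 1 from the core of compound 3. Compound 3 stands with the lowest number of the three measured, and its steps to the other two lie beyond the scatter.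

Compound 4, `COc1ccc(CN(C(=O)CSC(=S)N2CCN(C(C)=O)CC2)c2cc(OC)c(OC)c(OC)c2)cc1O`, joins both changes. It differs from compound 3 by acetyl in place of ethyl on an amine nitrogen in a ring, the same change that was measured from compound 1 to compound 2, at the same place in the ring. If that step carries over onto the core of compound 3, compound 4 is expected to show a 3.5-fold lower number from compound 3 to compound 4 (0.55 log units; beyond the scatter) in this assay, resting on a 5.6-fold lower number from compound 1 to compound 2 (0.75 log units; beyond the scatter). For the measured compounds named here, the expectation is tempered since compound 3 already sits low and only one example of the change has been measured. Compound 4 is therefore estimated at 150 nM, between 50 nM and 500 nM.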

Compound 4, half-maximal inhibitory concentration: 780 nM
The estimate for compound 4 lay 5.2-fold (0.72 log units) below the measured number; measured number outside the range, above it.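

On the core that already carries the hydroxy group, acetyl in place of ethyl on the ring nitrogen gave a 1.5-fold higher number from compound 3 to compound 4 (0.17 log units; within the scatter), so the step seen on the core of compound 1 did not carry over in this assay: the same change on two cores in this assay, a 5.6-fold lower number (0.75 log units; beyond the scatter) from compound 1 to compound 2 and a 1.5-fold higher number (0.17 log units; within the scatter) from compound 3 to compound 4, 8.3-fold (0.92 log units) apart, beyond the scatter of two such steps

Read the other way, hydroxy in place of hydrogen on an aromatic carbon gave a 1.8-fold lower number from compound 2 to compound 4 (0.24 log units; within the scatter) on the acetyl core, and this change did not carry over either: the same change on two cores in this assay, a 15-fold lower number (1.16 log units; beyond the scatter) from compound 1 to compound 3 and a 1.8-fold lower number (0.24 log units; within the scatter) from compound 2 to compound 4, 8.3-fold (0.92 log units) apart, beyond the scatter of two such steps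

The two changes therefore do not add up in these four compounds, since each moves the number beyond the scatter from compound 1 but not once the other is present; this single set of four gives no reason for that and no rule for any other core.

As far as these compounds go, it remains open whether a longer chain such as propyl, or a methanesulfonyl group, on the same ring nitrogen would follow the acetyl or the ethyl compounds. From the compounds shown here alone, it is equally open whether an amino group or a fluorine in place of the hydroxy group would show the same dependence on the core.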